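The compounds below may be only part of what the source reports. "The series", "measured", "known", "first", "only" and "open" are said of these compounds alone.

Compound 1 `Cn1c(Cc2nn(C)c(=O)c3ccccc23)nnc1SCC(=O)Nc1ccc(Cl)cc1Cl` gives 22500 nM in an assay on 32D cells for inhibition of interleukin-15 (Mus musculus), read by resazurin assay, with stated times of 30 min and 2.5 days, in the presence of a further agent that is not named here; a lower number here means a stronger inhibitor, a higher number a weaker inhibitor. Compound 2 `Cn1c(Cc2nn(C)c(=O)c3ccccc23)nnc1SCCCCCCCC(=O)Nc1ccc(Cl)cc1Cl` gives 2200 nM in this assay and stands second highest of the three numbers; its nearest neighbour is compound 3 `Cn1nc(Cc2nnc(SCCCCCCCC(=O)Nc3ccc(Cl)cc3Cl)[nH]2)c2ccccc2c1=O`, which gives 1100 nM in this assay, the furthest is compound 1. The step of a 2.0-fold lower number from compound 2 to compound 3 (0.30 log units; within the scatter) shows that a hydrogen in place of the methyl on the aromatic nitrogen leaves the number where it was. Compound 4 `Cn1nc(Cc2nnc(SCCCCCCCC(=O)Nc3ccc(Cl)cc3Cl)n2CCC(=O)O)c2ccccc2c1=O` differs from compound 2 by carboxymethyl in place of hydrogen on a saturated chain carbon bound to an aromatic nitrogen. Within the data shown here, the only step that bears on the same nitrogen, a 2.0-fold lower number from compound 2 to compound 3 (0.30 log units; within the scatter), was within the scatter, and nothing measured here speaks to a carboxylic acid on that chain. Compound 4 is therefore expected to stay close to compound 2, with a 1.1-fold higher number from compound 2 to compound 4 (0.06 log units; within the scatter), estimated at 2500 nM in this assay, range 800 nM to 8000 nM.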

Compound 4, half-maximal inhibitory concentration: 23500 nM
Compound 4: middle estimate off by 9.4-fold (0.97 log units), on the low side; the whole stated range lies below it.
By their numbers in this assay, from the lowest: compounds 3 and 2 (each within the scatter of the next); then compounds 1 and 4 (each within the scatter of the next).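

On the aromatic nitrogen, this assay separates substituents only once 2-carboxyethyl enters: methyl and hydrogen stay within the scatter of each other, while the acid-bearing chain gives an 11-fold higher number from compound 2 to compound 4 (1.03 log units; beyond the scatter) and a 21-fold higher number from compound 3 to compound 4 (1.33 log units; beyond the scatter). The position is therefore not indifferent to what it carries, which the step between compound 2 and compound 3 alone could not show. No evidence at hand gives a cause for this step.

Whether the carboxylic acid or the chain itself accounts for the step stays open. A plain propyl chain, the methyl ester or an amine on this nitrogen would tell these apart.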